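A few compounds are considered here, and "the series" means these few. Any claim that something is new, unique, unknown or untested is made for them only; others in the source may bear on it.

Series notes. The shared core of compound 1 `COc1ccc(C(=O)n2nnc3ccccc32)cc1` is kept throughout; in an assay for inhibition of Alpha amylase (Homo sapiens), with a stated time of 10 min (a lower number here means a stronger inhibitor, a higher number a weaker inhibitor), compound 1 gives 2980 nM. Compound 2 `O=C(c1ccc([N+](=O)[O-])cc1)n1nnc2ccccc21` gives 2920 nM in this assay, and compound 3 `Cc1cc(C(=O)n2nnc3ccccc32)ccc1[N+](=O)[O-]` gives 4080 nM. Compound 2 has the lowest of the three numbers, but its nearest neighbour compound 1 and its furthest neighbour compound 3 both sit within the scatter of it, so no order among the three can be claimed.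

The step to compound 4 `CCCCOc1ccc(C(=O)n2nnc3ccccc32)cc1` is butoxy in place of nitro on an aromatic carbon. The bearing measured step is a 1.0-fold lower number from compound 1 to compound 2 (0.01 log units; within the scatter), the only one at the same aromatic carbon, and it shows no shift beyond the scatter when one group replaces another there. The step of a 1.4-fold higher number from compound 2 to compound 3 (0.15 log units; within the scatter) sits elsewhere and also stays within the scatter. Among the compounds with values here, no measured pair speaks to a chain of the length of butoxy. Compound 4 is therefore expected to give about 3000 nM in this assay, within 1400 nM to 7000 nM, which means an expected step of a 1.0-fold higher number from compound 2 to compound 4 (0.01 log units; within the scatter).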

Compound 4, half-maximal inhibitory concentration: 5400 nM
Estimate against measurement, compound 4: 1.8-fold (0.26 log units) below, within the range that was stated.
By their numbers in this assay, from the lowest: compounds 2, 1, 3 and 4 (each within the scatter of the next).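

At the aromatic carbon para to a large group, butoxy in place of nitro gives a 1.8-fold higher number from compound 2 to compound 4 (0.27 log units; within the scatter) in this assay. Extending the chain from the methoxy of the core of compound 1, with propyl in place of hydrogen on the saturated chain carbon bound to the oxygen, gives a 1.8-fold higher number from compound 1 to compound 4 (0.26 log units; within the scatter), so this position now carries a chain as long as butoxy with no shift beyond the scatter, something the earlier compounds could not show. No supporting measurement accompanies these values to explain them.

On these data alone, whether a longer chain such as octyloxy, or an amine or a carboxylic acid, at this carbon would move the number beyond the scatter stays open. No change among the compounds shown yet marks a step beyond the scatter, so what this position demands of a group remains undefined.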